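Removing a chloro group from a sulfonyl acylguanidine series

The source may report more compounds than this note shows. Statements on the series, on what has been measured and on what is new or still open speak of the compounds shown alone.

Measured compounds:
compound 1 `Cc1cc(Cl)c(S(C)(=O)=O)cc1C(=O)N=C(N)N` — 25 nM
compound 2 `Cc1c(C(=O)N=C(N)N)cc(S(C)(=O)=O)c(Cl)c1Cl` — 29 nM
compound 3 `Cc1cc(Sc2ccc(Cl)cc2)c(S(C)(=O)=O)cc1C(=O)N=C(N)N` — 19 nM

In a functional assay for inhibition of sodium/hydrogen exchanger (Oryctolagus cuniculus) (on this read-out higher numbers stand for weaker inhibition and lower numbers for stronger inhibition), compound 1 gives 25 nM, compound 2 gives 29 nM and compound 3 gives 19 nM. Compound 1 arises from compound 2 by the change (hydrogen in place of chloro on an aromatic carbon), and this step reads a 1.2-fold lower number from compound 2 to compound 1 (0.06 log units; within the scatter). Compound 3 arises from compound 1 by a further change, with the step of a 1.3-fold lower number from compound 1 to compound 3 (0.12 log units; within the scatter). Compound 3 carries the lowest number of the three, but its neighbours stand close to it in this assay, so no order among them is claimed.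

Compound 4 `Cc1cc(Sc2ccccc2)c(S(C)(=O)=O)cc1C(=O)N=C(N)N` has not yet been measured. It differs from compound 3 by hydrogen in place of chloro on an aromatic carbon. This is the same kind of change as that from compound 2 to compound 1, but not the same: in the earlier case the place was ortho to a chloro group, ortho to a methyl group, meta to a group of 6 heavy atoms and meta to a methylsulfonyl group, whereas here it is para to a large group. The difference between the core of compound 2 and the core of compound 3 is not broken down here.

Because the earlier step of a 1.2-fold lower number from compound 2 to compound 1 (0.06 log units; within the scatter) was small, a similarly small step is expected for compound 4, namely a 1.2-fold higher number from compound 3 to compound 4 (0.06 log units; within the scatter). For compound 4 in this assay the estimate is 22 nM, expected to fall between 9 nM and 55 nM.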

Compound 4, half-maximal inhibitory concentration: 14 nM
Compound 4: middle estimate off by 1.6-fold (0.20 log units), on the high side, within the range that was stated.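

In this assay, taking the chloro off the 4-chlorophenyl group gives a 1.4-fold lower number from compound 3 to compound 4 (0.13 log units; within the scatter), and setting this beside the same change on the other core gives this reading: the same change on two cores in this assay, a 1.2-fold lower number (0.06 log units; within the scatter) from compound 2 to compound 1 and a 1.4-fold lower number (0.13 log units; within the scatter) from compound 3 to compound 4, 1.2-fold (0.07 log units) apart, within the scatter of two such steps. Across these two pairs, then, hydrogen in place of chloro leaves the number within the scatter on both cores, although the place differs, and the exchange of chloro on the shared core for phenylsulfanyl, a 1.8-fold lower number from compound 1 to compound 4 (0.25 log units; within the scatter), likewise allows no order between the two compounds. Among the compounds shown here, this shows only that the change carried over without a detectable difference in these two instances and in this one assay; it does not show that the change is without consequence on other cores or at other places, and two small steps cannot establish a rule for the series.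

The compounds shown carry only chloro or hydrogen at the place para to a large group, so it remains open whether a methoxy group, an amine or a carboxylic acid there would also stay within the scatter. On these data alone, it is also open whether a longer chain in place of the phenylsulfanyl group would keep the number in the same range.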